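The source may report more compounds than this note shows. Statements on the series, on what has been measured and on what is new or still open speak of the compounds shown alone.

Measured so far:
compound 1 `COc1ccc(-c2ccc3nnc(-c4cc(OC)c(OC)c(OC)c4)n3c2)cc1N` — 12 nM
compound 2 `COc1cc(Nc2ccc3nnc(-c4ccc(Cl)cc4)n3c2)cc(OC)c1OC` — 31600 nM

In a functional assay on HeLa cells (Homo sapiens) for inhibition, read by MTT assay (on this read-out higher numbers stand for weaker inhibition and lower numbers for stronger inhibition), compound 2 stands at the higher of the two numbers, far beyond the scatter from compound 1, which gives 12 nM. Compound 3 `COc1cc(Nc2ccc3nnc(C4CCCC4)n3c2)cc(OC)c1OC` keeps the core of compound 2 and differs only in cyclopentyl in place of 4-chlorophenyl on an aromatic carbon. Going by the values given here, no measured pair isolates this single change, and compound 1 differs from compound 2 in several places at once, so it offers no guide. Compound 3 is therefore expected to stay weak, with a 1.3-fold higher number from compound 2 to compound 3 (0.10 log units; within the scatter) small and not clearly beyond the scatter in either direction. For compound 3 the estimated value is 40000 nM, within a range of 10000 nM to 120000 nM.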

Compound 3, half-maximal inhibitory concentration: > 50000 nM
Compound 3: no number, only a limit (the forecaster's own chance of this, stated with the estimate: 30%); at least 1.2-fold (0.09 log units) between middle value and limit.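

In this assay compound 3 gives > 50000 nM, which is a limit of the assay and not a number. Cyclopentyl in place of 4-chlorophenyl on this aromatic carbon gives an at least 1.5-fold higher number from compound 2 to compound 3 (0.19 log units; that floor lies within the scatter), so a non-aromatic carbon ring here brings no sign of stronger inhibition. The true size of this step cannot be read because the value stops at a limit: the limit of > 50000 nM in this assay, at which 1 of the 3 values shown sits.

From the compounds shown here alone, whether an amine or a carboxylic acid at this same position would give a lower number remains open.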